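This account rests on a few compounds, and the source may have more. Where it says the series, first, only, none or still open, it means among the compounds named here.

Working notes on a small series built on one shared core. Compound 1 `CCOc1nc(-c2cc3ccccc3o2)cc(-c2ccc3ccccc3c2)c1C#N` in a functional assay on aorta (strain Wistar) for inhibition, with Thoracic aorta (Rattus norvegicus) as the target (a lower number here means a stronger inhibitor, a higher number a weaker inhibitor), gives 423000 nM. Compound 2 `COc1ccc(OC)c(-c2cc(-c3cc4ccccc4o3)nc(OC)c2C#N)c1` gives 246000 nM and compound 3 `COc1cc(-c2cc(-c3cc4ccccc4o3)nc(OC)c2C#N)cc(OC)c1OC` gives 310000 nM. Compound 1 stands highest of the three numbers, yet its gaps to compound 3 and to compound 2 both lie within the scatter, so no order among the three can be read. Within the data shown here, no pair of measured compounds differs in a single place, so no measured step is available. Compound 4 `CCOc1nc(-c2cc3ccccc3o2)cc(-c2cccs2)c1C#N` is not yet measured; it differs from compound 1 by thiophen-2-yl in place of naphthalen-2-yl on an aromatic carbon. With nothing in the series to show what this exchange does, the expected step of a 1.2-fold lower number from compound 1 to compound 4 (0.08 log units; within the scatter) is none beyond the scatter. Compound 4 is therefore estimated at 350000 nM, with a range of 150000 nM to 850000 nM.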

Compound 4, half-maximal inhibitory concentration: 308000 nM
Estimate against measurement, compound 4: 1.1-fold (0.06 log units) above; the range from low to high includes it.
By their numbers in this assay, from the lowest: compounds 2, 4, 3 and 1 (each within the scatter of the next).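

At this position, opposite the ring nitrogen, the change in this assay gives a 1.4-fold lower number from compound 1 to compound 4 (0.14 log units; within the scatter) and this step lies within the scatter. Two six-membered aromatic rings of carbon only can thus give way to one five-membered aromatic ring with 1 hetero atom without a readable change in this read-out. No measurement bears on the reason for this result. Going by these compounds, whether an amine, a carboxylic acid or a longer chain at this position would give a step beyond the scatter remains open.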